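A few compounds are considered here, and "the series" means these few. Any claim that something is new, unique, unknown or untested is made for them only; others in the source may bear on it.

Measured compounds in a functional assay on HeLa cells (Homo sapiens) for antiproliferative activity, read by MTT assay, with a stated time of 72 h; a higher number here means a weaker inhibitor, a lower number a stronger inhibitor:

compound 1, `O=C1O/C(=C\Cn2cc(-c3ccc(Br)cc3)nn2)C(OCc2ccccc2)=C1OCc1ccccc1`, gives 24300 nM
compound 2, `O=C1O/C(=C\Cn2cc(-c3cc(C(F)(F)F)cc(C(F)(F)F)c3)nn2)C(OCc2ccccc2)=C1OCc1ccccc1`, gives > 100000 nM
compound 3, `Cc1ccc(-c2cn(C[C@H](O)[C@H]3OC(=O)C(OCc4ccccc4)=C3OCc3ccccc3)nn2)cc1`, gives 25500 nM

Compound 1 holds the lowest of the two numbers shown; compound 3 sits within the scatter of it, so the two cannot be ranked. The value given for compound 2 is a limit of the assay, not a number.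

Compound 4, `O=C1O/C(=C\Cn2cc(-c3cccc(O)c3)nn2)C(OCc2ccccc2)=C1OCc1ccccc1`, differs from compound 1 by 3-hydroxyphenyl in place of 4-bromophenyl on an aromatic carbon. For the measured compounds named here, no step between measured compounds that changes only this group is available, so the size and direction of the step from compound 1 to compound 4 is not known from the measured data. The step of a 1.2-fold higher number from compound 1 to compound 4 (0.09 log units; within the scatter) is expected to lie within the scatter. Compound 4 is therefore estimated to give 30000 nM, with a range from 10000 nM to 100000 nM.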

Compound 4, half-maximal inhibitory concentration: 74800 nM
Estimate against measurement, compound 4: 2.5-fold (0.40 log units) below, and the stated range covers the measured number.
By their numbers in this assay, from the lowest: compounds 1 and 3 (each within the scatter of the next); then compound 4. At a limit, above all of these: compound 2.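

In this assay, replacing 4-bromophenyl with 3-hydroxyphenyl on the aromatic carbon of the five-membered ring gives a 3.1-fold higher number from compound 1 to compound 4 (0.49 log units; beyond the scatter). This first measured step shows that antiproliferative activity responds to the group at this position. The change alters both the substituent and where it sits on the phenyl ring, so these two effects cannot be separated, and nothing shown explains the step.

Going by these compounds, it remains open whether a phenyl ring carrying an amine or a carboxylic acid would be tolerated here.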